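Swapping Benzyloxy for Isobutyl on the Weakest Compound

The source may hold more compounds than are shown below. What is called first, only, known or untested is meant among the compounds shown, and "the series" means these compounds.

Measured so far:
Compound 1 `Cc1ccc([C@@H](C)Oc2cc3onc(CCC(=O)O)c3cc2Cl)nc1` gives 1.59 nM in an assay on HEK293 cells for inhibition of kynurenine 3-monooxygenase (Homo sapiens), read by LC-MS, with a stated time of 20 h; on this read-out higher numbers stand for weaker inhibition and lower numbers for stronger inhibition.
Compound 2 `C[C@@H](Oc1cc2onc(CCC(=O)O)c2cc1Cl)c1ccc(F)cn1` gives 31.6 nM in this assay.
Compound 3 `O=C(O)CCn1c(=O)oc2cc(OCc3ccccc3)c(Cl)cc21` gives 1580 nM in this assay.

Compound 3 stands at the highest number of the three, and so is the weakest inhibitor here: its gap to compound 2 and its gap to compound 1 both lie beyond the scatter. Going by the values given here, the only step between compounds differing in one place is a 20-fold higher number from compound 1 to compound 2 (1.30 log units; beyond the scatter), a change on the aromatic ring at the far end of compound 1, on a core that compound 3 does not share. It tells nothing direct about the change studied now.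

Compound 4 `CC(C)Cc1cc2oc(=O)n(CCC(=O)O)c2cc1Cl` differs from compound 3 as follows: isobutyl in place of benzyloxy on an aromatic carbon. Among the compounds with values here, no measured pair shows a benzyloxy group giving way to an isobutyl group, so there is no step to lean on. Compound 3 is already the weakest compound, and the group that leaves is the only one of its kind among the three measured structures. The expectation is therefore cautious: the number for compound 4 is estimated to stay near that of compound 3 or rise, a step of a 2.2-fold higher number from compound 3 to compound 4 (0.35 log units; beyond the scatter). Compound 4 is expected to give about 3500 nM, within a range from 900 nM to 14000 nM.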

Compound 4, half-maximal inhibitory concentration: 794 nM
Compound 4: the middle estimate sits 4.4-fold (0.64 log units) above what was measured; the measured number lies below the stated range.
By their numbers in this assay, from the lowest: compound 1; then compound 2; then compounds 4 and 3 (each within the scatter of the next).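

In this assay, replacing benzyloxy with isobutyl gives a 2.0-fold lower number from compound 3 to compound 4 (0.30 log units; within the scatter), so the two compounds cannot be told apart on this read-out. Going by these compounds alone, this is the first look at this position, on an aromatic carbon ortho to a chloro group, and it shows that a large structural change need not move the number on this core: benzyloxy has 8 heavy atoms, an aromatic ring and a hydrogen-bond acceptor, while isobutyl has 4 heavy atoms, no ring and no acceptor. Nothing at hand explains why the two compounds read alike.

As far as these compounds go, with only these two groups at this position, it remains open whether an amine, a carboxylic acid or a chain longer than isobutyl would give a number clearly different from those of compound 3 and compound 4. From the compounds shown here alone, it also remains open whether isobutyl would read the same way on the core of compound 1, since this one pair says nothing about how the change behaves on another core.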